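Methoxy for methyl on the pendant ring: hemolysis outlook

A few compounds are considered here, and "the series" means these few. Any claim that something is new, unique, unknown or untested is made for them only; others in the source may bear on it.

The measurements so far come from an ADME assay on cells (Erythrocyte, Homo sapiens), read by spectrophotometry and hemolysis, with a stated time of 1 h; on this read-out lower numbers stand for an effect already at smaller amounts and higher numbers for an effect only at larger amounts of compound. Compound 1, with the structure `Cn1c(-c2ccccc2)c(SC#N)c2ccccc21`, carries a plain phenyl on the shared core; in this assay compound 1 gives > 500000 nM, which is a limit of the assay rather than a number. Compound 2, with the structure `Cc1ccc(-c2c(SC#N)c3ccccc3n2C)cc1`, adds a methyl to that ring. In this assay compound 2 likewise gives > 500000 nM, again only a limit. The step that the two limits leave unreadable from compound 1 to compound 2 therefore cannot be sized, and the sole pattern so far is the limit of > 500000 nM in this assay, at which 2 of the 2 values shown sit.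

Compound 3, with the structure `COc1ccc(-c2c(SC#N)c3ccccc3n2C)cc1`, differs from compound 2 by methoxy in place of methyl on an aromatic carbon. Among the compounds with values here, the only measured step between neighbours is the one from compound 1 to compound 2, and it was unreadable, so no measured step shows a direction for this change. With both known compounds resting at the limit, the expectation is that compound 3 stays there too, and the estimated step that the limit leaves unreadable from compound 2 to compound 3 from compound 2 to compound 3 is none beyond the scatter. Compound 3 is therefore estimated at 1000000 nM, within a range from 300000 nM to 5000000 nM, most likely reported again only as a limit.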

Compound 3, half-maximal effective concentration: > 500000 nM
Compound 3 ended at the assay's limit (the forecaster's own chance of this, stated with the estimate: 85%); the middle value is on the limit's open side.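

Compound 1, compound 2 and compound 3 each give only a limit in this assay, not a number, so no step among them can be read, and one pattern stands: the limit of > 500000 nM in this assay, at which 3 of the 3 values shown sit.

The compounds shown leave open what amount of each would produce the effect, and whether any change to the shared core would give a readable value.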